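Swapping trifluoromethyl for methoxy on a fused aromatic ring

A few compounds are considered here, and "the series" means these few. Any claim that something is new, unique, unknown or untested is made for them only; others in the source may bear on it.

Measured compounds:
compound 1, `COc1ccc(-n2nc(C(=O)NCC(=O)Nc3nc4ccc(OC)cc4s3)c3ccccc3c2=O)cc1`, 60 nM
compound 2, `O=C(CNC(=O)c1nn(-c2ccc(F)cc2)c(=O)c2ccccc12)Nc1nc2ccc(C(F)(F)F)cc2s1`, 90 nM

Both numbers come from an assay on L cells for inhibition of Protein-serine O-palmitoleoyltransferase porcupine (Mus musculus), read by reporter gene assay, with a stated time of 24 h; a higher number here means that more compound is needed for the effect, a lower number that less compound is needed. Compound 2 sits at the upper end of the two, yet its gap to compound 1 lies within the usual scatter of repeated measurements, so the two cannot be told apart. For the measured compounds named here, the two structures differ in more than one place, so no single step between them is available.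

Compound 3, `COc1ccc2nc(NC(=O)CNC(=O)c3nn(-c4ccc(F)cc4)c(=O)c4ccccc34)sc2c1`, is not yet measured. It differs from compound 2 in one place: methoxy in place of trifluoromethyl on an aromatic carbon. Since compound 1 and compound 2 give numbers that the scatter does not separate, the pair offers no evidence that this kind of exchange moves this assay far. Compound 3 is therefore expected to stay close to compound 2, with a step of a 1.4-fold lower number from compound 2 to compound 3 (0.14 log units; within the scatter), if anything slightly downward. The estimate for compound 3 is 65 nM, with a range from 25 nM to 170 nM.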

Compound 3, half-maximal effective concentration: 90 nM
Beside the measured number, compound 3's estimate is 1.4-fold (0.14 log units) below it, and the stated range covers the measured number.
By their numbers in this assay, from the lowest: compounds 1, 2 and 3 (each within the scatter of the next).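

In this assay, for the compounds shown here, methoxy in place of trifluoromethyl on this aromatic carbon gives no change at the digits printed from compound 2 to compound 3 (within the scatter), so this is the first comparison at this position with nothing else altered, and the two groups cannot be told apart here. Compound 3 also isolates a second single change, fluoro in place of methoxy on an aromatic carbon, which gives a 1.5-fold higher number from compound 1 to compound 3 (0.18 log units; within the scatter), so neither of the two differences between compound 1 and compound 2 shows a measurable effect when read alone. Nothing shown explains why these groups read alike.

Both groups at this position are small and uncharged, so an amine, a carboxylic acid or a longer alkyl chain there remains an open test. Plain hydrogen at the same carbon would show whether any group is needed there at all.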